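A few compounds are considered here, and "the series" means these few. Any claim that something is new, unique, unknown or untested is made for them only; others in the source may bear on it.

In a functional assay on DLD-1 cells (Homo sapiens) for cytotoxicity, with a stated time of 48 h (on this read-out lower numbers stand for stronger inhibition and higher numbers for weaker inhibition), three compounds sharing one core have been measured. Compound 1 `CCCCCOc1ccc2oc(/C=C/[S+](C)[O-])cc(=O)c2c1` gives 6600 nM, compound 2 `C[S+]([O-])/C=C/c1cc(=O)c2ccccc2o1` gives 8000 nM, and compound 3 `COc1ccc2oc(/C=C/[S+](C)[O-])cc(=O)c2c1` gives 5700 nM. Compound 3 therefore stands level with the other two, as all three values lie within the scatter of one another.

The next structure is compound 4 `C[S+]([O-])/C=C/c1cc(=O)c2cc(OC(=O)C(C)(C)C)ccc2o1`, which differs from compound 3 in one place: (tert-butyl)carbonyl in place of methyl on an oxygen on an aromatic ring. In words, methoxy becomes ((tert-butyl)carbonyl)oxy.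

Among the measured compounds shown here, three measured steps bear on this place. These are a 1.2-fold higher number from compound 1 to compound 2 (0.08 log units; within the scatter), a 1.2-fold lower number from compound 1 to compound 3 (0.06 log units; within the scatter) and a 1.4-fold lower number from compound 2 to compound 3 (0.15 log units; within the scatter). Each stays within the scatter, even with hydrogen, methoxy and pentyloxy exchanged there. For the measured compounds named here, none of the measured compounds carries a (tert-butyl)carbonyl, however, so the new group remains untested and the range must stay wide.

On this evidence, no change beyond the scatter is expected, and no direction is favoured. The expected step is a 1.1-fold higher number from compound 3 to compound 4 (0.02 log units; within the scatter). The estimated value for compound 4 is 6000 nM, within an expected range of 2500 nM to 14000 nM.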

Compound 4, half-maximal inhibitory concentration: 8000 nM
Compound 4: the middle estimate sits 1.3-fold (0.12 log units) below what was measured, within the range that was stated.
By their numbers in this assay, from the lowest: compounds 3, 1, 2 and 4 (each within the scatter of the next).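

In this assay, exchanging methoxy for ((tert-butyl)carbonyl)oxy gives a 1.4-fold higher number from compound 3 to compound 4 (0.15 log units; within the scatter), putting (tert-butyl)carbonyl in place of pentyl on the same oxygen gives a 1.2-fold higher number from compound 1 to compound 4 (0.08 log units; within the scatter), and putting ((tert-butyl)carbonyl)oxy in place of hydrogen gives no change at the digits printed from compound 2 to compound 4 (within the scatter). The position therefore accepts a group containing a carbonyl as well as hydrogen, methoxy and pentyloxy, with all four compounds staying within the scatter of one another, so this read-out does not separate these groups. No supporting measurement is available to explain why the position makes so little difference.

As far as these compounds go, whether this flat picture would hold for a group of a different kind here, such as an amine or a carboxylic acid, remains open. The compounds shown vary only this one place, so the effect of a change elsewhere on the shared core is also open.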